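The compounds below may be only part of what the source reports. "The series", "measured", "known", "first", "only" and "open" are said of these compounds alone.

The study gathers four compounds built on one shared core. In a functional assay on P388 cells (Mus musculus) for cytotoxicity (a lower number here means a stronger inhibitor, a higher number a weaker inhibitor), compound 1 (`COc1ccc2c(c1)c(-c1cc(C(F)(F)F)c(C#N)c(-c3cn(S(=O)(=O)c4ccc(C)cc4)c4ccc(OC)cc34)n1)cn2S(=O)(=O)c1ccc(C)cc1`) reaches only a limit of the assay, > 100000 nM. Compound 2 (`COc1ccc2c(-c3cc(C(F)(F)F)c(C#N)c(-c4cn(S(=O)(=O)c5ccc(C)cc5)c5cc(OC)ccc45)n3)cn(S(=O)(=O)c3ccc(C)cc3)c2c1`) likewise returns only a limit, > 100000 nM. Compound 3 (`Cc1ccc(S(=O)(=O)n2cc(-c3cc(C(F)(F)F)cc(-c4cn(S(=O)(=O)c5ccc(C)cc5)c5cc(Br)ccc45)n3)c3ccc(Br)cc32)cc1`) stands at that same limit, > 100000 nM. Among the compounds with values here, all that this assay shows so far is the limit of > 100000 nM in this assay, at which 3 of the 3 values shown sit, so no step between measured compounds can be drawn. Compound 4 (`Cc1ccc(S(=O)(=O)n2cc(-c3cc(C(F)(F)F)c(C#N)c(-c4cn(S(=O)(=O)c5ccc(C)cc5)c5cc(Br)ccc45)n3)c3ccc(Br)cc32)cc1`) is not yet measured; it differs from compound 3 by cyano in place of hydrogen on an aromatic carbon, a cyano in place of hydrogen on an aromatic carbon. With every value a limit, the step of a number no higher from compound 3 to compound 4 (the limit leaves the size open) is expected to show no direction beyond the scatter. Compound 4 is therefore estimated at 100000 nM, within 50000 nM to 300000 nM, most likely reported again only as a limit.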

Compound 4, half-maximal inhibitory concentration: > 100000 nM
Compound 4: a limit, no number; the forecaster's own chance of this, stated with the estimate: 90%; the middle value lies on the limit itself.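

Within the data shown here, no step from compound 3 to compound 4 can be read in this assay, because both compounds stand at the same limit of the assay: the limit of > 100000 nM in this assay, at which 4 of the 4 values shown sit. The compounds shown leave open how the four rank against one another and whether cyano in place of hydrogen on an aromatic carbon changes the read-out at all.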